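Swapping the Base: Expected Cytotoxicity of Compound 3

The source may report more compounds than this note shows. Statements on the series, on what has been measured and on what is new or still open speak of the compounds shown alone.

Compound 1 `CCS[C@@H]1[C@H](SCC)[C@@H](Cn2cc(-c3ccccc3)nn2)O[C@H]1n1ccc(=O)[nH]c1=O`: 8380 nM
Compound 2 `CCS[C@@H]1[C@H](SCC)[C@@H](Cn2cc(-c3cccc(C)c3)nn2)O[C@H]1n1ccc(=O)[nH]c1=O`: 18300 nM

In a functional assay on HepG2 cells (Homo sapiens) for cytotoxicity, read by MTT assay, with a stated time of 72 h (a lower number here means that less compound is needed, a higher number that more compound is needed for the effect), compound 1 gives 8380 nM, the lowest of the two numbers. Compound 2 gives 18300 nM; the step of a 2.2-fold higher number from compound 1 to compound 2 (0.34 log units; beyond the scatter) comes from a methyl in place of hydrogen on an aromatic carbon. Compound 3 `CCS[C@@H]1[C@H](SCC)[C@@H](Cn2cc(-c3ccccc3)nn2)O[C@H]1n1ccc(N)nc1=O` carries a different change: a group of 8 heavy atoms (4 carbon, 3 nitrogen, 1 oxygen; one six-membered aromatic ring with 2 hetero atoms) in place of a group of 8 heavy atoms (4 carbon, 2 nitrogen, 2 oxygen; one six-membered aromatic ring with 2 hetero atoms), on a saturated ring carbon, on a saturated ring carbon next to the ring oxygen. Going by the values given here, no measured step touches this exchange, so the data give no direction for it. The expectation for compound 3 is therefore a step of a 1.2-fold higher number from compound 1 to compound 3 (0.08 log units; within the scatter), within the scatter. Compound 3 is estimated at 10000 nM, with a range of 3000 nM to 40000 nM.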

Compound 3, half-maximal effective concentration: 57100 nM
Beside the measured number, compound 3's estimate is 5.7-fold (0.76 log units) below it, and the stated range ends below it.
By their numbers in this assay, from the lowest: compound 1; then compound 2; then compound 3.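

The base position, on a saturated ring carbon next to the ring oxygen, turns out not to be neutral: exchanging the group there for one with 3 nitrogen and 1 oxygen atoms gives a 6.8-fold higher number from compound 1 to compound 3 (0.83 log units; beyond the scatter) in this assay. Going by these compounds alone, this is the first measured sign that cytotoxicity here depends on this group, and it takes more compound to reach the effect with the new group in place. No other measurement shown accounts for this step. As far as these compounds go, whether a chlorine atom on this six-membered aromatic ring would bring the number down remains open, as does the effect of a longer chain in place of an ethylsulfanyl group.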